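The source may hold more compounds than are shown below. What is called first, only, known or untested is meant among the compounds shown, and "the series" means these compounds.

Compound 1 `CCN(CC)C(=O)COc1ccc(-c2cc(=O)c3c(O)c(O)c(O)cc3o2)cc1`: in a physicochemical assay, read by spectrophotometry (a lower number here means a stronger inhibitor, a higher number a weaker inhibitor), compound 1 gives 81300 nM.
Compound 2 `CC(C)N(C(=O)Oc1ccc(-c2cc(=O)c3c(O)c(O)c(O)cc3o2)cc1)C(C)C`: in this assay compound 2 gives 17000 nM.
Compound 3 `CN(C)CCCOc1ccc(-c2cc(=O)c3c(O)c(O)c(O)cc3o2)cc1`: in this assay compound 3 gives 231000 nM.

Compound 3 has the highest number of the three: a 2.8-fold higher number from compound 1 to compound 3 (0.45 log units; beyond the scatter) and a 14-fold higher number from compound 2 to compound 3 (1.13 log units; beyond the scatter), both beyond the scatter. Compound 4 `CN(C)C(=O)COc1ccc(-c2cc(=O)c3c(O)c(O)c(O)cc3o2)cc1` is not yet measured; it differs from compound 3 in one place: dimethylcarbamoyl in place of 2-(dimethylamino)ethyl on a saturated chain carbon bound to an oxygen on an aromatic ring. The step that bears most directly on this change runs the other way: a 2.8-fold higher number from compound 1 to compound 3 (0.45 log units; beyond the scatter), where a carbamoyl gave way to an amine on the same chain carbon and the number rose modestly. Reversing the sense of that change in compound 4 should therefore lower the number modestly from compound 3; compound 1, which carries the diethyl counterpart of the group entering compound 4, gives a useful anchor, and the other step, a 4.8-fold lower number from compound 1 to compound 2 (0.68 log units; beyond the scatter), shows that carbamoyl variants differ among themselves by only a modest amount. For compound 4 the expected step is a 2.9-fold lower number from compound 3 to compound 4 (0.46 log units; beyond the scatter). Compound 4 is thus estimated at 80000 nM, with a likely range of 35000 nM to 180000 nM.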

Compound 4, half-maximal inhibitory concentration: 80700 nM
Compound 4: middle estimate off by 1.0-fold (0.00 log units), on the low side; the range from low to high includes it.
By their numbers in this assay, from the lowest: compound 2; then compounds 4 and 1 (each within the scatter of the next); then compound 3.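

In this assay, replacing 3-(dimethylamino)propyl with (dimethylcarbamoyl)methyl on the oxygen lowers the number (a 2.9-fold lower number from compound 3 to compound 4 (0.46 log units; beyond the scatter)), so the shift seen earlier with the diethyl amide also appears with the dimethyl amide. The new comparison on the carbonyl carbon, dimethylamino in place of diethylamino, shows no change beyond the scatter (a 1.0-fold lower number from compound 1 to compound 4 (0.00 log units; within the scatter)), so at this position the two amines cannot be told apart. The gap to the diisopropylcarbamoyl group on the oxygen remains beyond the scatter (a 4.7-fold higher number from compound 2 to compound 4 (0.68 log units; beyond the scatter)), and it appears with the dimethyl amide as it did with the diethyl amide.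

From the compounds shown here alone, it remains open how a pyrrolidine amide, an amide that keeps its amide hydrogen, or a longer chain between the oxygen and the carbonyl would read. Nothing available accounts for any of these steps.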